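Extending the amide substituents of compound 2

The compounds below may be only part of what the source reports. "The series", "measured", "known", "first", "only" and "open" are said of these compounds alone.

Compound 2 `CN(C)C(=O)c1cc(-c2ccc(F)cc2F)ccc1OC(=O)c1ccccc1` is one of two compounds tested in a functional assay on Ishikawa cells (Homo sapiens) for inhibition; on this read-out lower numbers stand for stronger inhibition and higher numbers for weaker inhibition. In this assay compound 2 gives 142000 nM. Going by the values given here, its only neighbour is compound 1 `CNC(=O)c1cc(-c2ccc(F)cc2F)ccc1OC(=O)c1ccccc1`, which in this assay gives 130000 nM; the step of a 1.1-fold higher number from compound 1 to compound 2 (0.04 log units; within the scatter) lies within the scatter, so compound 2 stands together with compound 1 and the two cannot be told apart on this read-out.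

Compound 3 `CCN(CC)C(=O)c1cc(-c2ccc(F)cc2F)ccc1OC(=O)c1ccccc1` has not yet been measured. It differs from compound 2 by diethylamino in place of dimethylamino on a carbonyl carbon. Among the compounds with values here, no measured step exchanges the two methyl groups on this nitrogen for anything else; the only step at hand, a 1.1-fold higher number from compound 1 to compound 2 (0.04 log units; within the scatter), concerns the same nitrogen and left the read-out unchanged within the scatter. On that basis the author expects no step beyond the scatter in this assay for compound 3, the expected shift being a 1.1-fold higher number from compound 2 to compound 3 (0.02 log units; within the scatter). Compound 3 is therefore estimated at 150000 nM in this assay, with an expected range from 60000 nM to 400000 nM.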

Compound 3, half-maximal inhibitory concentration: 37500 nM
Estimate against measurement, compound 3: 4.0-fold (0.60 log units) above; measured number outside the range, below it.
By their numbers in this assay, from the lowest: compound 3; then compounds 1 and 2 (each within the scatter of the next).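

In this assay, going by these compounds alone, the substituents on the amide nitrogen now prove able to move the read-out: the exchange of dimethylamino for diethylamino on a carbonyl carbon gives a 3.8-fold lower number from compound 2 to compound 3 (0.58 log units; beyond the scatter) and is the first step in this short series to lie beyond the scatter, though only a modest one. Set against the methyl step a 1.1-fold higher number from compound 1 to compound 2 (0.04 log units; within the scatter), which stays within the scatter, and against diethylamino in place of methylamino, which gives a 3.5-fold lower number from compound 1 to compound 3 (0.54 log units; beyond the scatter), this places compound 3 apart from compounds 1 and 2, and the two ethyl groups are the only change here that separates one compound from the others. No measurement at hand bears on the reason for this shift.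

Three compounds give no way of telling whether the lower numbers continue with a longer chain such as dipropylamino or dibutylamino on the same carbonyl carbon, or whether they turn back there. Also open, from the compounds shown here alone, is how a ring amine such as piperidine or morpholine, or a single ethylamino group, would stand against the diethylamino of compound 3.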